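Urea series: removing one trifluoromethyl from compound 2

This account rests on a few compounds, and the source may have more. Where it says the series, first, only, none or still open, it means among the compounds named here.

Of the compounds shown here, two have numbers so far. Compound 1 `O=C(Nc1cccc(-n2cc(-c3ccncc3)c(-c3cc(O)cc(Cl)c3)n2)c1)Nc1ccc(Cl)c(Cl)c1` and compound 2 `COc1cc(Cl)cc(-c2nn(-c3cccc(NC(=O)Nc4cc(C(F)(F)F)cc(C(F)(F)F)c4)c3)cc2-c2ccncc2)c1` share the same core and were both run in a functional assay on SW-620 cells (Homo sapiens) for inhibition, read by sulforhodamine B assay, with a stated time of 48 h, tested at 0.1 uM; on this read-out lower numbers stand for a stronger effect and higher numbers for a weaker effect at the one concentration tested. In this assay compound 1 gives 99%, and compound 2 gives 94%; the gap between the two lies within the usual scatter, so neither can be set apart from the other on these numbers. Compound 2 holds the lower of the two figures, with compound 1 close beside it.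

Compound 3 `COc1cc(Cl)cc(-c2nn(-c3cccc(NC(=O)Nc4cccc(C(F)(F)F)c4)c3)cc2-c2ccncc2)c1` is the next member to be run. It differs from compound 2 in one place: hydrogen in place of trifluoromethyl on an aromatic carbon, on an aromatic carbon of a six-membered aromatic ring of carbon only. Going by the values given here, no pair of measured compounds shows what such a change does in this assay, so no measured step can be leaned on. The expected step from compound 2 to compound 3 in this assay is a number 1 percentage points higher from compound 2 to compound 3 (within the scatter), that is, none beyond the scatter. For compound 3 in this assay the estimate is 95%, with a range from 80% to 105%.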

Compound 3, a percentage reported as activity, at one concentration (the size of the read-out at that concentration, not a potency): 100%
Compound 3: middle estimate off by 5 percentage points, on the low side, within the range that was stated.
By their numbers in this assay, from the lowest: compounds 2, 1 and 3 (each within the scatter of the next).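

In this assay, going by these compounds alone, hydrogen in place of trifluoromethyl on an aromatic carbon of the six-membered aromatic ring of carbon only gives a number 6 percentage points higher from compound 2 to compound 3 (within the scatter), the first measured step at this position. On this single-concentration read-out, compound 2 and compound 3 therefore cannot be set apart, and this one trifluoromethyl group shows no effect beyond the scatter. No measurement available here bears on the reason for this result.

Still open, from the compounds shown here alone, is whether another group on this carbon, such as an amine, a carboxylic acid or a longer alkyl chain, would give a step beyond the scatter. Also open, going by these compounds, is whether compound 2 and compound 3 would remain inseparable at any concentration other than the one tested.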